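The compounds below may be only part of what the source reports. "The series", "measured", "known", "first", "only" and "open" are said of these compounds alone.

Three compounds have numbers in a functional assay on U-251 cells (Homo sapiens) for inhibition, read by sulforhodamine B assay, with a stated time of 72 h; a lower number here means that less compound is needed, a higher number that more compound is needed for the effect. Compound 1 (`O=C(/C=C/c1ccc([N+](=O)[O-])o1)c1ccc(C2CCCCC2)cc1`) gives 4400 nM, compound 2 (`CC(C)(C)c1ccc(C(=O)/C=C/c2ccco2)cc1`) gives 16400 nM, and compound 3 (`CCCCc1ccc(C(=O)/C=C/c2ccco2)cc1`) gives 6400 nM. Compound 3 thus lies within the scatter of compound 1 and clearly apart from compound 2. For the measured compounds named here, the one measured step with a single change is a 2.6-fold lower number from compound 2 to compound 3 (0.41 log units; beyond the scatter), a modest step beyond the scatter, with butyl in place of tert-butyl on an aromatic carbon.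

The compound still without a number is compound 4 (`O=C(/C=C/c1ccco1)c1ccc(C2CCCCC2)cc1`), which has cyclohexyl in place of butyl on an aromatic carbon. Going by the values given here, no measured step makes this exact exchange. Among the compounds with values here, the step to compound 3 shows only that a change at this place has moved the number modestly, as a 2.6-fold lower number from compound 2 to compound 3 (0.41 log units; beyond the scatter) records. Compound 1 carries the same cyclohexyl and gives 4400 nM, though its core differs from that of compound 4. Neither points firmly in one direction, so no shift beyond the scatter is expected. The expected change is a 1.1-fold lower number from compound 3 to compound 4 (0.03 log units; within the scatter), which would stay within the scatter. In this assay, compound 4 is estimated at 6000 nM, with an expected range from 2500 nM to 14000 nM.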

Compound 4, half-maximal effective concentration: 26400 nM
Compound 4: the middle estimate sits 4.4-fold (0.64 log units) below what was measured; measured number outside the range, above it.
By their numbers in this assay, from the lowest: compounds 1 and 3 (each within the scatter of the next); then compounds 2 and 4 (each within the scatter of the next).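

In this assay the exchange at this place on the aromatic ring is not neutral, since cyclohexyl in place of butyl gives a 4.1-fold higher number from compound 3 to compound 4 (0.62 log units; beyond the scatter) and so moves the number beyond the scatter. The ring and tert-butyl are not told apart at this place, with a 1.6-fold higher number from compound 2 to compound 4 (0.21 log units; within the scatter) lying within the scatter, so among compounds 2, 3 and 4 only butyl, in compound 3, stands apart from the other two. The step with hydrogen in place of nitro, a 6.0-fold higher number from compound 1 to compound 4 (0.78 log units; beyond the scatter), shows that with cyclohexyl held fixed the second place on the molecule also moves the number beyond the scatter, so the value of compound 1 could not stand in for cyclohexyl on the shared core.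

Nothing among the data offers an account of these differences. As far as these compounds go, it remains open whether a longer chain such as hexyl or a smaller ring such as cyclopentyl would fall with butyl or with cyclohexyl, and whether nitro would bring a comparable step with butyl or tert-butyl at the first place.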